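The source may hold more compounds than are shown below. What is called first, only, known or untested is meant among the compounds shown, and "the series" means these compounds.

Measured compounds in a functional assay on HT-29 cells (Homo sapiens) for cytotoxicity, read by MTT assay, with a stated time of 72 h; on this read-out lower numbers stand for higher toxicity in this test and higher numbers for lower toxicity in this test:
compound 1 `CC(C)COC(=O)Nc1ccc([Se][Se]c2ccc(NC(=O)OCC(C)C)cc2)cc1` gives 77400 nM;
compound 2 `C=CCOC(=O)Nc1ccc([Se]C#N)cc1` gives 72800 nM;
compound 3 `O=C(Nc1ccc([Se][Se]c2ccc(NC(=O)Oc3ccc(F)cc3)cc2)cc1)Oc1ccc(F)cc1` gives 85300 nM.

All three numbers lie within the usual scatter of one another, so no order among them can be claimed. Compound 2 carries the lowest number of the three, but its nearest neighbour compound 1 and its furthest neighbour compound 3 both sit within the scatter of it, and nothing here separates the three compounds in this assay. Going by the values given here, no pair among the measured compounds differs in a single place, so no measured step is available for guidance.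

Compound 4 `N#C[Se]c1ccc(NC(=O)Oc2ccccc2)cc1` is the untested member. It differs from compound 2 by phenyl in place of allyl on an oxygen next to a carbonyl group. Among the compounds with values here, the only hint on a change at this oxygen comes from compound 1 and compound 3, which carry different groups there within diselenide frameworks and give values within the scatter of each other; that comparison is not a single-place step and is taken only loosely.

For compound 4 the expected step of a 1.0-fold higher number from compound 2 to compound 4 (0.01 log units; within the scatter) is no change beyond the scatter. The estimate for compound 4 in this assay is 75000 nM, with a range from 35000 nM to 160000 nM.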

Compound 4, concentration lethal to 50% of the cells: 71700 nM
Estimate against measurement, compound 4: 1.0-fold (0.02 log units) above; low and high end bracket the measured number.
By their numbers in this assay, from the lowest: compounds 4, 2, 1 and 3 (each within the scatter of the next).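

Phenyl in place of allyl on an oxygen next to a carbonyl group is the first single-place step in the series, and in this assay it reads a 1.0-fold lower number from compound 2 to compound 4 (0.01 log units; within the scatter) with the rest of compound 2 held constant. Going by these compounds alone, at this oxygen, then, the read-out does not distinguish allyl, with its double bond outside aromatic rings, from phenyl, with its six-membered aromatic ring of carbon only, a direct comparison that the earlier compounds did not offer. This is a single pair on a single framework, and nothing measured alongside it speaks to why the number stays put.

As far as these compounds go, it remains open whether a longer chain, a benzyl group or a chain ending in an amine on this oxygen would also leave the number unmoved, and whether a substituted phenyl would do so on the framework of compound 4. With all four numbers in this assay lying within the scatter of their neighbours, the compounds shown also include no example of a change at any place that clearly moves this read-out.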